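The compounds below may be only part of what the source reports. "The series", "measured", "known", "first", "only" and "open" are said of these compounds alone.

In a functional assay for inhibition, read by spectrophotometry, with a stated time of 20 min, tested at 3 mg/mL (a lower number here means a weaker effect, a higher number a stronger effect of the compound at the concentration tested), compound 1 `CC(=O)c1ccc(NC(=O)C(CC(C)C)N(C(=O)c2ccccc2)S(=O)(=O)c2ccc(C)cc2)cc1` gives 63.1%. Compound 3 `CC(=O)c1ccc(NC(=O)C(CC(C)C)N(C(=O)c2ccccc2)S(=O)(=O)c2ccc([N+](=O)[O-])cc2)cc1` differs from compound 1 by nitro in place of methyl on an aromatic carbon; in this assay compound 3 gives 62.3%, so a number 0.8 percentage points lower from compound 1 to compound 3 (within the scatter). Compound 2 `CC(=O)c1ccc(NC(=O)C2CC(O)CN2S(=O)(=O)c2ccc(C)cc2)cc1` is built on another core; the difference between the two cores is not broken down here. In this assay compound 2 gives 12.7%, the lowest of the three numbers and beyond the scatter from both others. Compound 4 `CC(=O)c1ccc(NC(=O)C2CC(O)CN2S(=O)(=O)c2ccc([N+](=O)[O-])cc2)cc1` is not yet measured and differs from compound 2 by nitro in place of methyl on an aromatic carbon, the same change at the same place as that from compound 1 to compound 3. That earlier change gave a number 0.8 percentage points lower from compound 1 to compound 3 (within the scatter). A similarly small step is therefore expected, a number 0.7 percentage points lower from compound 2 to compound 4 (within the scatter). Compound 4 is estimated at 12% in this assay, most likely between 3% and 25%.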

Compound 4, a percentage reported as inhibition, at one concentration (the size of the read-out at that concentration, not a potency): 58.7%
Compound 4: the middle estimate sits 46.7 percentage points below what was measured, and the stated range ends below it.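

In this assay, nitro in place of methyl gives a number 46 percentage points higher from compound 2 to compound 4 (beyond the scatter), so the same change did not behave alike on the two cores: the same change on two cores in this assay, a number 0.8 percentage points lower (within the scatter) from compound 1 to compound 3 and a number 46 percentage points higher (beyond the scatter) from compound 2 to compound 4, 46.8 percentage points apart, beyond the scatter of two such steps. A step measured on one core was therefore no reliable guide to the same step on the other core in this series. These two pairs do not show why the cores differ, and they say nothing about any other core or any other group.

The compounds shown carry only methyl or nitro at this place. As far as these compounds go, it remains open whether the jump on the core of compound 2 is particular to nitro or would also appear with another group, such as a nitrile or an amine.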